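Shortening the Chain: From Compound 3 to Compound 4

The compounds below may be only part of what the source reports. "The series", "measured", "known", "first", "only" and "open" are said of these compounds alone.

Compound 1 `COc1cccc(N2CCN(C(=O)C(C)N3C(=O)CCC3=O)CC2)c1`: 50%
Compound 2 `CC(C(=O)N1CCN(c2ccc(Cl)cc2)CC1)N1C(=O)CCC1=O`: 100%
Compound 3 `CCC(C(=O)N1CCN(c2cccc(C)c2)CC1)N1C(=O)CCC1=O`: 100%

All three were tested in a functional assay on the whole organism (strain Swiss) with Mus musculus as the target, in the maximal electroshock model, with a stated time of 0.5 h, at a dose of 300 mg/kg by the intraperitoneal route; on this read-out lower numbers stand for a weaker effect and higher numbers for a stronger effect at the one dose given. Compound 3 stands level with compound 2, the two together at the top of the three, while compound 1 lies below both, beyond the scatter. Compound 4 `Cc1cccc(N2CCN(C(=O)C(C)N3C(=O)CCC3=O)CC2)c1` differs from compound 3 in one place: hydrogen in place of methyl on a saturated chain carbon, two bonds along the chain from an amide-type nitrogen in a ring and a carbonyl carbon. For the measured compounds named here, the only measured step, a number 50 percentage points higher from compound 1 to compound 2 (beyond the scatter), changes the aryl group and does not bear on this chain change; compounds 2 and 3 differ in two places, so their matching values do not isolate it. Compounds 1 and 2 both carry the shorter chain, and their values show it compatible with either the top response or a lower one. Going by the values given here, with no guiding step, a small downward shift a number 15 percentage points lower from compound 3 to compound 4 (beyond the scatter) is expected. Compound 4 is estimated at 85%, between 45% and 100%.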

Compound 4, a percentage reported as activity, at one dose (the size of the read-out at that dose, not a potency): 50%
Compound 4: middle estimate off by 35 percentage points, on the high side, and the stated range covers the measured number.
By their numbers in this assay, from the lowest: compounds 1 and 4 (each within the scatter of the next); then compounds 2 and 3 (each within the scatter of the next).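

In this assay the chain change can now be read on its own: with the aryl group held fixed, going from ethyl to methyl at this carbon loses much of the response (a number 50 percentage points lower from compound 3 to compound 4 (beyond the scatter)). With the methyl chain, the aryl group matters too: 3-methylphenyl in place of 4-chlorophenyl gives a large loss (a number 50 percentage points lower from compound 2 to compound 4 (beyond the scatter)), whereas methyl and methoxy on the aromatic carbon read alike (no change at the digits printed from compound 1 to compound 4 (within the scatter)). Nothing measured here explains these steps.

Still open, on these data alone, is whether a longer chain, such as propyl, keeps the response at this carbon. As far as these compounds go, it is also open whether ethyl matters as much alongside 4-chlorophenyl.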